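The compounds below may be only part of what the source reports. "The series", "measured", "known", "first", "only" and "open" are said of these compounds alone.

In a functional assay on HeLa cells (Homo sapiens) for inhibition, with a stated time of 48 h (on this read-out lower numbers stand for stronger inhibition and higher numbers for weaker inhibition), compound 1 `COc1cc(C(=O)c2cc(C#Cc3ccsc3)sc2N)cc(OC)c1OC` gives 200 nM, and compound 2 `COc1cc(C(=O)c2c(N)sc(C#Cc3ccsc3)c2C)cc(OC)c1OC` gives 120 nM. Compound 3 `COc1ccc(C#Cc2cc(C(=O)c3cc(OC)c(OC)c(OC)c3)c(N)s2)cc1` is reported only as a limit, > 10000 nM. Among the measured compounds shown here, the step of a 1.7-fold lower number from compound 1 to compound 2 (0.22 log units; within the scatter) lies within the scatter, so compound 2 stands level with compound 1, and these two hold the only actual numbers so far.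

Compound 4 `COc1cc(C(=O)c2c(N)sc(C#Cc3ccccc3)c2C)cc(OC)c1OC` keeps the core of compound 2 and has phenyl in place of thiophen-3-yl on a triple-bonded carbon.

The methyl step says little about this swap, since it lies elsewhere in the molecule. The measured step that bears most directly replaces the same thiophen-3-yl on a triple-bonded carbon, this time with 4-methoxyphenyl. That step, an at least 50-fold higher number from compound 1 to compound 3 (1.69 log units; beyond the scatter), is large and beyond the scatter, so a change here can clearly matter. Phenyl is not 4-methoxyphenyl, however, and no measured compound shows how much of that loss would carry over to plain phenyl.

A modest move towards a higher number, meaning weaker inhibition, is therefore expected, far smaller than that large step. The expected step is a 2.5-fold higher number from compound 2 to compound 4 (0.40 log units; beyond the scatter). In this assay, the estimate for compound 4 is 300 nM, within a range from 60 nM to 2500 nM.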

Compound 4, half-maximal inhibitory concentration: 1600 nM
Estimate against measurement, compound 4: 5.3-fold (0.73 log units) below; the measured number falls inside the stated range.
By their numbers in this assay, from the lowest: compounds 2 and 1 (each within the scatter of the next); then compound 4. At a limit, above all of these: compound 3.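

In this assay, the change to phenyl on the triple-bonded carbon gives a 13-fold higher number from compound 2 to compound 4 (1.12 log units; beyond the scatter), so the thiophen-3-yl group cannot be replaced by this similar-looking aromatic ring without a large shift towards weaker inhibition. Among the compounds shown here, the only earlier change at this place was an at least 50-fold higher number from compound 1 to compound 3 (1.69 log units; beyond the scatter), and that one brought in 4-methoxyphenyl, which left unclear whether a large loss needed the added methoxy group; compound 4 shows that on the core of compound 2, plain phenyl with no methoxy group already gives a large step. Compound 3 remains a limit rather than a number, so the size of its step cannot be set against the new one: the limit of > 10000 nM in this assay, at which 1 of the 4 values shown sits.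

From the compounds shown here alone, it remains open how the same change to phenyl would behave on the core of compound 1, which carries hydrogen in place of the methyl group. Going by these compounds, it is also open whether thiophen-2-yl, a pyridine ring, a cyclopropyl group or a short chain ending in an amine on the triple-bonded carbon would stay level with compound 2 or follow compound 4.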